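The source may report more compounds than this note shows. Statements on the series, on what has been measured and on what is new or still open speak of the compounds shown alone.

Measured in a functional assay on K562 cells (Homo sapiens) for inhibition, read by trypan blue exclusion, with a stated time of 72 h; a higher number here means a weaker inhibitor, a lower number a stronger inhibitor:
- compound 1 `Cn1c(=O)c(S(=O)(=O)Cc2ccc(F)cc2F)cc2cnc(Nc3ccc4[nH]ccc4c3)nc21`: 1000 nM
- compound 2 `COc1ccc(S(=O)(=O)c2cc3cnc(Nc4ccc5[nH]ccc5c4)nc3n(C)c2=O)cc1`: 300 nM

Compound 2 has the lower of these two numbers, 300 nM, which makes it the stronger inhibitor of the pair. The next compound to consider is compound 3 `Cn1c(=O)c(S(=O)(=O)c2ccc(O)cc2)cc2cnc(Nc3ccc4[nH]ccc4c3)nc21`, and the change is small: hydrogen in place of methyl on an oxygen on an aromatic ring. In other words, methoxy becomes hydroxy, turning 4-methoxyphenyl into 4-hydroxyphenyl.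

For the measured compounds named here, only one measured step offers any guidance. This is a 3.3-fold lower number from compound 1 to compound 2 (0.52 log units; beyond the scatter), a modest step beyond the scatter, in which 4-methoxyphenyl took the place of 2,4-difluorobenzyl on a sulfonyl sulfur. That step swapped a whole group, whereas here only a methyl leaves. Going by the values given here, no measured pair tests the methoxy group alone, so the data give no firm direction for this change.

In this assay, the expected result is therefore little or no movement beyond the scatter, with the estimated step being a 1.2-fold higher number from compound 2 to compound 3 (0.07 log units; within the scatter). For compound 3 the estimated value is 350 nM, with an expected range of 100 nM to 1000 nM.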

Compound 3, half-maximal inhibitory concentration: 100 nM
Beside the measured number, compound 3's estimate is 3.5-fold (0.54 log units) above it; the range from low to high includes it.
By their numbers in this assay, from the lowest: compound 3; then compound 2; then compound 1.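

In this assay, taking only the methyl off the oxygen gives a 3.0-fold lower number from compound 2 to compound 3 (0.48 log units; beyond the scatter) and this step lies beyond the scatter, so the change from methoxy to hydroxy is not a silent one. The earlier step had replaced a whole group on the sulfonyl sulfur and could not show what the methoxy group alone contributes, whereas this pair isolates that single difference. Set against the 2,4-difluorobenzyl group, the 4-hydroxyphenyl group gives a 10-fold lower number from compound 1 to compound 3 (1.00 log units; beyond the scatter) and so has the lowest number of the three compounds, with its steps to both others beyond the scatter, while nothing available explains why removing the methyl has this result.

The compounds shown leave open how an amine, a carboxylic acid or a longer chain such as ethoxy would read in place of the hydroxy group on the same phenyl ring. They also leave open whether the step from methoxy to hydroxy would be of similar size on a different core, as all three compounds share the same one.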